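Trifluoromethyl for chloro at the limit of the assay

The source may report more compounds than this note shows. Statements on the series, on what has been measured and on what is new or still open speak of the compounds shown alone.

Measured in a functional assay on HeLa cells (Homo sapiens) for inhibition, read by sulforhodamine B assay, with a stated time of 74 h; a lower number here means a stronger inhibitor, a higher number a weaker inhibitor:
- compound 1 `Cc1ccccc1S(=O)(=O)N1C(=O)COC12C=CC(=O)C=C2`: 3720 nM
- compound 2 `O=C1C=CC2(C=C1)OCC(=O)N2S(=O)(=O)c1ccc(Cl)cc1`: > 10000 nM (a limit, not a number)

Compound 2 gives > 10000 nM, which is a limit of this assay and not a number. The two-compound series therefore contains (the limit of > 10000 nM in this assay, at which 1 of the 2 values shown sits). For the measured compounds named here, its only true number belongs to compound 1, at 3720 nM.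

Compound 3 `O=C1C=CC2(C=C1)OCC(=O)N2S(=O)(=O)c1ccc(C(F)(F)F)cc1` keeps the core of compound 2 and carries trifluoromethyl in place of chloro on an aromatic carbon, para to a large group: trifluoromethyl in place of chloro on an aromatic carbon.

Going by the values given here, one measured step bears on this change, and only indirectly: an at least 2.6-fold higher number from compound 1 to compound 2 (0.42 log units; beyond the scatter). As far as these compounds go, that step lies beyond the scatter, but it ends at a limit, so its full size remains open. Among the compounds with values here, it also replaces a different group, and no measured pair tests chloro against trifluoromethyl. The expectation is therefore that compound 3 stays close to compound 2 in this assay, with no step beyond the scatter in either direction. The expected change is a step that the limit leaves unreadable from compound 2 to compound 3.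

Compound 3 is estimated at 12000 nM, with an expected range from 4000 nM to 35000 nM.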

Compound 3, half-maximal inhibitory concentration: 770 nM
Beside the measured number, compound 3's estimate is 16-fold (1.19 log units) above it; the measured number lies below the stated range.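

In this assay this place on the aromatic ring proves sensitive to the group it carries: trifluoromethyl in place of chloro gives an at least 12-fold lower number from compound 2 to compound 3 (1.11 log units; beyond the scatter), a large step beyond the scatter. Compound 2 stands at a limit and not a number, so this step fixes only a minimum size and its full size cannot be read: the limit of > 10000 nM in this assay, at which 1 of the 3 values shown sits.

Compound 3, at 770 nM, gives the series its first true number for a group on this aromatic carbon, para to a large group. The earlier step could not give such a number: it replaced a different group and ended at the limit of compound 2.

The compounds shown do not tell whether this response belongs to trifluoromethyl in particular or would appear with other groups in the same place, such as a nitrile, a methoxy group or an amine. They also leave open whether a plain hydrogen in this place would read closer to compound 2 or to compound 3, and so whether chloro or trifluoromethyl is the group that departs from the unsubstituted ring.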